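Adding isopropyl to compound 1: working notes

A few compounds are considered here, and "the series" means these few. Any claim that something is new, unique, unknown or untested is made for them only; others in the source may bear on it.

Measured in a functional assay on MDA-MB-231 cells (Homo sapiens) for antiproliferative activity, read by MTT assay, with a stated time of 72 h; on this read-out lower numbers stand for stronger inhibition and higher numbers for weaker inhibition:
- compound 1 `O=C(CCc1cccc2c1B(O)OC2)Nc1ccccc1`: 230 nM
- compound 2 `O=C(CCc1cccc2c1B(O)OC2)Nc1ccc(Cl)cc1`: 3600 nM
- compound 3 `O=C(CCc1cccc2c1B(O)OC2)Nc1ccc([N+](=O)[O-])cc1`: 36000 nM

Compound 1 has the lowest number of the three, and its aromatic ring bears no added group. Chloro in place of hydrogen gives a 16-fold higher number from compound 1 to compound 2 (1.19 log units; beyond the scatter), a large step. Nitro in place of hydrogen gives a 160-fold higher number from compound 1 to compound 3 (2.19 log units; beyond the scatter), also large. Nitro in place of chloro adds a 10-fold higher number from compound 2 to compound 3 (1.00 log units; beyond the scatter), a modest step. Among these three compounds, both replacements of hydrogen raise the number, and no measured compound goes against this.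

Compound 4 `CC(C)c1cccc(NC(=O)CCc2cccc3c2B(O)OC3)c1` is still to be measured. Its difference from compound 1 is isopropyl in place of hydrogen on an aromatic carbon. This is isopropyl in place of hydrogen on an aromatic carbon, meta to a large group. Among the compounds with values here, no measured compound carries isopropyl, and the two steps from compound 1 are only a loose guide. A rise in the number is expected on the evidence of compound 2 with a 16-fold higher number from compound 1 to compound 2 (1.19 log units; beyond the scatter), and the nitro step is treated as the less close precedent. The expected change is a 6.5-fold higher number from compound 1 to compound 4 (0.81 log units; beyond the scatter). The estimated value for compound 4 is 1500 nM, with an expected range from 300 nM to 8000 nM.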

Compound 4, half-maximal inhibitory concentration: 1600 nM
Beside the measured number, compound 4's estimate is 1.1-fold (0.03 log units) below it; the measured number falls inside the stated range.
By their numbers in this assay, from the lowest: compound 1; then compound 4; then compound 2; then compound 3.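

In this assay, isopropyl in place of hydrogen, meta to a large group, gives a 7.0-fold higher number from compound 1 to compound 4 (0.84 log units; beyond the scatter), so a group of 3 carbon atoms with 0 hydrogen-bond donors and 0 hydrogen-bond acceptors also raises the number relative to the unsubstituted aromatic ring of compound 1. This is the first measured change at this place, and it extends the earlier pattern: all three replacements of hydrogen now give a higher number than compound 1, and no compound shown goes against this. No measured property of isopropyl or of the other groups is available to explain this step, so the result stands as an observation without a stated cause.

The compounds shown leave open whether a smaller group such as methyl, or a group carrying nitrogen or oxygen such as an amine or a carboxylic acid, would raise the number at this same place. They also leave open how much of the step belongs to isopropyl itself and how much to its place, as isopropyl appears at only one place on this aromatic ring.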